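Replacing 1H-pyrrol-1-yl with ethoxy in compound 3

A few compounds are considered here, and "the series" means these few. Any claim that something is new, unique, unknown or untested is made for them only; others in the source may bear on it.

In an ADME assay on the whole organism (strain Han-Wistar) for pharmacokinetics, with Rattus norvegicus as the target, read by LC-MS, at a dose of 2 mg/kg by the oral route (a higher number here means more compound in the circulation at the dose given, a lower number less compound in the circulation), compound 3 (`CN1CCN(CCCS(=O)(=O)c2ccc3nc(NC(=O)NC(=O)c4cc(-n5cccc5)ccc4Cl)sc3c2)CC1`) gives 580 nM, the middle of three numbers. Compound 1 (`CCN(CC)CCCS(=O)(=O)c1ccc2nc(NC(=O)NC(=O)c3cc(-n4cccn4)ccc3Cl)sc2c1`) gives 1600 nM, and compound 2 (`Cc1cc(C)n(-c2ccc(Cl)c(C(=O)NC(=O)Nc3nc4ccc(S(=O)(=O)CCCN5CCN(C)CC5)cc4s3)c2)n1`) gives 78 nM. Compound 4 (`CCOc1ccc(Cl)c(C(=O)NC(=O)Nc2nc3ccc(S(=O)(=O)CCCN4CCN(C)CC4)cc3s2)c1`) has ethoxy in place of 1H-pyrrol-1-yl on an aromatic carbon. Going by the values given here, one measured step bears on this change: a 7.4-fold higher number from compound 2 to compound 3 (0.87 log units; beyond the scatter), which swapped 3,5-dimethyl-1H-pyrazol-1-yl for 1H-pyrrol-1-yl on that carbon. Among the compounds with values here, it shows that a swap there can move this assay, but no measured compound carries ethoxy, so its size and direction do not carry over. Only a slight fall, inside the scatter, is expected: a 1.7-fold lower number from compound 3 to compound 4 (0.22 log units; within the scatter). Compound 4 is estimated at 350 nM, with an expected range of 120 nM to 1000 nM.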

Compound 4, maximal plasma concentration: 4200 nM
Compound 4: middle estimate off by 12-fold (1.08 log units), on the low side; the measured number lies above the stated range.
By their numbers in this assay, from the lowest: compound 2; then compound 3; then compound 1; then compound 4.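

In this assay, ethoxy on this aromatic carbon, para to a chloro group, gives a higher number than either five-membered aromatic ring (a 7.2-fold higher number from compound 3 to compound 4 (0.86 log units; beyond the scatter)) and (a 54-fold higher number from compound 2 to compound 4 (1.73 log units; beyond the scatter)). Going by these compounds alone, the earlier step compared only two rings, so it did not show that a small group with no ring could rise above both. No measurement shown explains this rise.

As far as these compounds go, it remains open whether the oxygen or the loss of the ring matters more. A propyl chain, a methoxy group or a longer alkoxy chain at this carbon could help separate the two.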